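Series notes: removing the nitro group, expected cytotoxicity

The source may report more compounds than this note shows. Statements on the series, on what has been measured and on what is new or still open speak of the compounds shown alone.

Three compounds have numbers in an ADME assay on HEL cells (Homo sapiens) for cytotoxicity; on this read-out higher numbers stand for lower toxicity in this test and lower numbers for higher toxicity in this test. Compound 1 `O=C(COc1cccc2ccccc12)N/N=C/c1cccc([N+](=O)[O-])c1` gives 61.2 ug/mL. Compound 2 `C/C(=N\NC(=O)COc1cccc2ccccc12)c1ccc(O)cc1O` gives 74.8 ug/mL, and compound 3 `COc1ccc(/C=N/NC(=O)COc2cccc3ccccc23)cc1O` gives 27.7 ug/mL. Compound 1 stands second highest of the three: the nearest number is that of compound 2, within the usual scatter of repeated measurements, and the furthest is that of compound 3, beyond it. Within the data shown here, no pair of measured compounds differs in one place only, so no step between measured compounds in this assay is available.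

Compound 4 `O=C(COc1cccc2ccccc12)N/N=C/c1ccccc1` has not yet been measured in this assay. It differs from compound 1 in a single place: hydrogen in place of nitro on an aromatic carbon. Among the measured compounds shown here, the measured compounds offer no step that isolates such a change, and compounds 2 and 3 differ from compound 1 in several places at once. For this assay a small step is expected, in no firm direction, most likely within the scatter.

Compound 4 is therefore estimated to give about 65 ug/mL in this assay, with a range from 35 ug/mL to 130 ug/mL. The estimated step of a 1.1-fold higher number from compound 1 to compound 4 (0.03 log units; within the scatter) is expected to stay within the scatter.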

Compound 4, half-maximal cytotoxic concentration: 64.5 ug/mL
The estimate for compound 4 lay 1.0-fold (0.00 log units) above the measured number; low and high end bracket the measured number.
By their numbers in this assay, from the lowest: compound 3; then compounds 1, 4 and 2 (each within the scatter of the next).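

Among these compounds, the step of a 1.1-fold higher number from compound 1 to compound 4 (0.02 log units; within the scatter) is the first single-place comparison in this assay, and it lies within the scatter. On this aromatic carbon, meta to a large group, hydrogen and nitro therefore cannot be told apart on this read-out, so the nitro group is not required for the number seen with compound 1. No measured data bear on the reason for this result.

As far as these compounds go, whether the same holds for an amine or a carboxylic acid on this carbon, or for a nitro group elsewhere on the ring, remains open. Compound 3 gives 27.7 ug/mL and differs from compound 4 in more than one place, so its number cannot yet be tied to any single change.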